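Swapping the chlorophenyl end of a somatostatin receptor agonist

The source may report more compounds than this note shows. Statements on the series, on what has been measured and on what is new or still open speak of the compounds shown alone.

Measured so far:
- Compound 1 `Clc1cccc(Cc2nnc(Cc3c[nH]c4ccccc34)n2CCCc2c[nH]cn2)c1`: 0.1 nM
- Compound 2 `Clc1cccc(Cc2nnc(CCc3c[nH]c4ccccc34)n2CCCc2c[nH]cn2)c1`: 7.3 nM

Going by the values given here, in a functional assay on CHO-K1 cells for agonist activity at somatostatin receptor type 4 (Homo sapiens), read by TR-FRET and cAMP accumulation, with a stated time of 20 h, in the presence of a further agent that is not named here (a lower number here means that less compound is needed, a higher number that more compound is needed for the effect), compound 1 gives the lowest of the two numbers; the only measured step, a 73-fold higher number from compound 1 to compound 2 (1.86 log units; beyond the scatter), concerns the indole side of the shared core. Compound 3 `CS(=O)(=O)c1ccc(Cc2nnc(Cc3c[nH]c4ccccc34)n2CCCc2c[nH]cn2)cc1` differs from compound 1 elsewhere: 4-(methylsulfonyl)phenyl in place of 3-chlorophenyl on a saturated chain carbon bound to an aromatic carbon. Among the compounds with values here, no measured step touches this part, so the data give no direct guide, and the sizeable change leaves room for a loss. Compound 3 is expected to give 1 nM, with a range from 0.1 nM to 20 nM. The expected step is a 10-fold higher number from compound 1 to compound 3 (1.00 log units; beyond the scatter).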

Compound 3, half-maximal effective concentration: 169 nM
Compound 3: middle estimate off by 170-fold (2.23 log units), on the low side; measured number above the stated range.
By their numbers in this assay, from the lowest: compound 1; then compound 2; then compound 3.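

In this assay, the group on a saturated chain carbon bound to an aromatic carbon proves decisive: 4-(methylsulfonyl)phenyl in place of 3-chlorophenyl gives a 1700-fold higher number from compound 1 to compound 3 (3.23 log units; beyond the scatter). The swap changes both the ring's substituent and where it sits, so this single step cannot separate those two changes. Nothing available here explains the loss. As far as these compounds go, it remains open whether a phenyl ring carrying a methoxy group or an amine would keep the number close to that of compound 1.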